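Cytotoxicity on colon cells: benzylamide analogue of compound 2

The source may hold more compounds than are shown below. What is called first, only, known or untested is meant among the compounds shown, and "the series" means these compounds.

The series shares one core, seen in compound 2 `CCc1ccc(NC(=O)c2cccc(/C=C3\CC(=O)N(c4ccccc4)C3=O)c2)cc1`, compound 1 `CCCCCN1C(=O)C/C(=C\c2cccc(C(=O)Nc3ccc(C)cc3)c2)C1=O` and compound 3 `CCc1cccc(NC(=O)c2cccc(/C=C3\CC(=O)N(Cc4ccccc4)C3=O)c2)c1`. In an ADME assay on NCM460 cells (Homo sapiens) for cytotoxicity, read by MTT assay, with a stated time of 72 h (on this read-out lower numbers stand for stronger inhibition and higher numbers for weaker inhibition), compound 2 gives > 100000 nM, which is a limit of the assay and not a number. In this assay compound 1 gives > 100000 nM, likewise a limit. In this assay compound 3 gives > 100000 nM, again a limit. For the measured compounds named here, this is summed up by the limit of > 100000 nM in this assay, at which 3 of the 3 values shown sit; with every reading resting there, compound 2 cannot be placed above or below the other two, and no step between measured compounds can be taken from these data.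

Compound 4 `O=C(NCc1ccccc1)c1cccc(/C=C2\CC(=O)N(c3ccccc3)C2=O)c1` differs from compound 2 by benzyl in place of 4-ethylphenyl on an amide-type nitrogen — benzyl in place of 4-ethylphenyl on an amide-type nitrogen; the same difference, cut one bond further out, reads (4-ethylphenyl)amino to benzylamino. Going by the values given here, no measured pair connects a change of this kind to a shift in this assay, and the measured values give no direction to follow.

The step from compound 2 to compound 4 is expected to be a number no higher from compound 2 to compound 4 (the limit leaves the size open), none beyond the scatter. Compound 4 is therefore estimated at 100000 nM, within a range from 30000 nM to 300000 nM, and is most likely to be reported again only as a limit.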

Compound 4, half-maximal inhibitory concentration: > 100000 nM
Compound 4: a limit, no number; the forecaster's own chance of this, stated with the estimate: 90%; the middle value sits exactly at the limit.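

In this assay compound 4 gives > 100000 nM as a limit of the assay and not a number. No step from compound 2 to compound 4 can be read, because both rest at the same limit: the limit of > 100000 nM in this assay, at which 4 of the 4 values shown sit.

The compounds shown leave open how they rank against one another, and whether benzyl in place of 4-ethylphenyl on an amide-type nitrogen shifts this read-out at all.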